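Moving a methyl group on a glutamate receptor modulator

This account rests on a few compounds, and the source may have more. Where it says the series, first, only, none or still open, it means among the compounds named here.

Three compounds have been measured in an assay on HEK293 cells for positive allosteric modulation of metabotropic glutamate receptor 2 (Rattus norvegicus), read by thallium flux, with a stated time of 2.5 min; on this read-out higher numbers stand for an effect only at larger amounts of compound and lower numbers for an effect already at smaller amounts:

compound 1, `Cc1cc(C(=O)O)ccc1OCCCCOc1ccc(C(=O)CC(C)C)c(O)c1C`: 192 nM
compound 2, `Cc1cc(OCCCCOc2ccc(C(=O)CC(C)C)c(O)c2C)ccc1C(=O)O`: 173 nM
compound 3, `Cc1cc(C(=O)O)ccc1OCCCCOc1ccc(C(=O)CC2CCCC2)c(O)c1C`: 608 nM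

Compounds 1 and 2 share a core and differ only in where a methyl group sits on the acid-bearing ring. That difference is 4-carboxy-3-methylphenyl in place of 4-carboxy-2-methylphenyl on an oxygen on a saturated carbon. It made a 1.1-fold lower number from compound 1 to compound 2 (0.05 log units; within the scatter), so the two compounds cannot be told apart in this assay.

Compound 3 is built on a different core. Relative to compound 1 the core differs by cyclopentyl in place of isopropyl on a saturated chain carbon bound to a carbonyl carbon, and this made a 3.2-fold higher number from compound 1 to compound 3 (0.50 log units; beyond the scatter). Compound 3 thus gives the highest number of the three measured compounds.

Compound 4, `Cc1cc(OCCCCOc2ccc(C(=O)CC3CCCC3)c(O)c2C)ccc1C(=O)O`, has not yet been measured. It stands to compound 3 as compound 2 stands to compound 1: the change is 4-carboxy-3-methylphenyl in place of 4-carboxy-2-methylphenyl on an oxygen on a saturated carbon, and it sits at the same place in both pairs, so it is the same change, here carried onto the core of compound 3.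

Because the same change made a 1.1-fold lower number from compound 1 to compound 2 (0.05 log units; within the scatter), compound 4 is expected to stay close to compound 3, with a step of about a 1.1-fold lower number from compound 3 to compound 4 (0.04 log units; within the scatter). This rests on a single earlier pair, so the expectation is tentative. For compound 4 the estimate in this assay is 550 nM, with a likely range from 250 nM to 1200 nM.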

Compound 4, half-maximal effective concentration: 564 nM
Compound 4: middle estimate off by 1.0-fold (0.01 log units), on the low side; the measured number falls inside the stated range.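

In this assay, putting 4-carboxy-3-methylphenyl in place of 4-carboxy-2-methylphenyl on the core of compound 3 gave a 1.1-fold lower number from compound 3 to compound 4 (0.03 log units; within the scatter), so these two compounds cannot be told apart, and the same change behaved alike on both cores: the same change on two cores in this assay, a 1.1-fold lower number (0.05 log units; within the scatter) from compound 1 to compound 2 and a 1.1-fold lower number (0.03 log units; within the scatter) from compound 3 to compound 4, 1.0-fold (0.01 log units) apart, within the scatter of two such steps The other change, cyclopentyl in place of isopropyl, gave a 3.3-fold higher number from compound 2 to compound 4 (0.51 log units; beyond the scatter) with the methyl group in its new place, and it too kept its size: the same change on two cores in this assay, a 3.2-fold higher number (0.50 log units; beyond the scatter) from compound 1 to compound 3 and a 3.3-fold higher number (0.51 log units; beyond the scatter) from compound 2 to compound 4, 1.0-fold (0.01 log units) apart, within the scatter of two such steps Among these four compounds, then, each change gives much the same step whichever form the other place takes, but the methyl move is a step within the scatter on both cores, so it shows only that the move made no readable difference here, and two cores cannot show that the same would hold on others.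

As far as these compounds go, it remains open whether the methyl group on the acid-bearing ring matters at all, which a ring with a chlorine or a methoxy group in its place, or with only hydrogen there, could test. From the compounds shown here alone, it is also open how far the cyclopentyl result extends, for instance to a cyclohexyl or a tert-butyl group, and whether the carboxylic acid could give way to an amide.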